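A few compounds are considered here, and "the series" means these few. Any claim that something is new, unique, unknown or untested is made for them only; others in the source may bear on it.

Measured so far in a functional assay on MDA-MB-231 cells (Homo sapiens) for cytotoxicity, read by sulforhodamine B assay, with a stated time of 3 days; on this read-out lower numbers stand for an effect already at smaller amounts and higher numbers for an effect only at larger amounts of compound:
Compound 1 `COCc1c(C)coc1-c1ccc2c(c1OC)CCCC2(C)C` gives 47.8 uM.
Compound 2 `CCOc1c(-c2occ(C)c2CO)ccc2c1CCCC2(C)C` gives 39.8 uM.
Compound 3 `Cc1coc(-c2ccc3c(c2O)CCCC3(C)C)c1CO` gives 39.5 uM.

Compound 1 has the highest of the three numbers, but its gaps to compound 2 and to compound 3 are small and lie within the usual scatter, so the three compounds cannot be told apart on these data. Among the measured compounds shown here, the only step between measured compounds that differ in one place, from compound 2 to compound 3, was a 1.0-fold lower number from compound 2 to compound 3 (0.00 log units; within the scatter); it concerns hydrogen in place of ethyl on an oxygen on an aromatic ring and so speaks to a different part of the shared core.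

Compound 4 `COc1c(-c2occ(C)c2C(=O)O)ccc2c1CCCC2(C)C` arises from compound 1 by a change on the five-membered aromatic ring: carboxy in place of methoxymethyl on an aromatic carbon. For the measured compounds named here, no measured step covers this exchange, so the expectation for compound 4 rests on the flat picture of the three measured compounds, which all gave close numbers in this assay despite changes elsewhere on the core. Compound 4 is therefore expected to give 60 uM, with a likely range from 25 uM to 150 uM, which means an expected step of a 1.3-fold higher number from compound 1 to compound 4 (0.10 log units; within the scatter) that is not clearly beyond the scatter.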

Compound 4, concentration for half-maximal effect: > 61 uM
Compound 4: a limit, no number (the forecaster's own chance of this, stated with the estimate: 25%); middle value at least 1.0-fold (0.00 log units) away from the limit.
By their numbers in this assay, from the lowest: compounds 3, 2 and 1 (each within the scatter of the next). At a limit, above all of these: compound 4.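

Carboxy in place of methoxymethyl gives the only step shown at this aromatic carbon of the five-membered aromatic ring, a position that no earlier pair of compounds covered. In this assay, compound 4 gives > 61 uM, which is a limit of the assay and not a number. The step reads as an at least 1.2-fold higher number from compound 1 to compound 4 (0.10 log units; that floor lies within the scatter), so the exchange gave no lower number, but the true distance between the two compounds stays unknown, and the only reading of this kind among the compounds shown is this one: the limit of > 61 uM in this assay, at which 1 of the 4 values shown sits.

From the compounds shown here alone, it remains open whether an amide, an amine or a longer ether chain on this same aromatic carbon would give a number inside the range of the assay, and so show how much this position tolerates. Going by these compounds, it also remains open whether carboxy would give a similar result with hydrogen or ethyl on the oxygen on an aromatic ring, the groups carried there by compound 3 and compound 2.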